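The source may report more compounds than this note shows. Statements on the series, on what has been measured and on what is new or still open speak of the compounds shown alone.

Working notes on the series. The three measured esters share one core and differ only in the halogen. In a functional assay on HT-1080 cells (Homo sapiens), read by transwell migration, with a stated time of 24 h, tested at 1 uM (on this read-out higher numbers stand for a weaker effect at the one concentration tested and lower numbers for a stronger effect), compound 1 `NCc1ccc2oc(=O)c(C(=O)Oc3cccc(Cl)c3)cc2c1` gives 86.6%, compound 2 `NCc1ccc2oc(=O)c(C(=O)Oc3cccc(Br)c3)cc2c1` gives 79.3% and compound 3 `NCc1ccc2oc(=O)c(C(=O)Oc3cccc(I)c3)cc2c1` gives 25.3%. The halogen steps run a number 7.3 percentage points lower from compound 1 to compound 2 (within the scatter), a number 61.3 percentage points lower from compound 1 to compound 3 (beyond the scatter) and a number 54 percentage points lower from compound 2 to compound 3 (beyond the scatter), so compound 3 stands lowest of the three, beyond the scatter from both others.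

Compound 4 `CC(=O)NCc1ccc2oc(=O)c(C(=O)Oc3cccc(I)c3)cc2c1` keeps the iodo of compound 3; the change is acetyl in place of hydrogen on an amine nitrogen. For the measured compounds named here, no measured step touches the amine nitrogen, so none bears on this change, and no direction can be read from the series. Compound 4 is expected at 38%, between 12% and 75%. The step is expected to be a number 12.7 percentage points higher from compound 3 to compound 4 (beyond the scatter).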

Compound 4, a percentage reported as activity, at one concentration (the size of the read-out at that concentration, not a potency): 23.5%
Beside the measured number, compound 4's estimate is 14.5 percentage points above it, within the range that was stated.
By their numbers in this assay, from the lowest: compounds 4 and 3 (each within the scatter of the next); then compounds 2 and 1 (each within the scatter of the next).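

In this assay the change gives a number 1.8 percentage points lower from compound 3 to compound 4 (within the scatter) and so stays within the scatter. For the compounds shown here, this is the first measured change at the amine nitrogen, and it shows that, with the iodo kept, acetamidomethyl in place of aminomethyl leaves the read-out where compound 3 stood. No measured property bears on this result.

On these data alone, whether acetyl on this nitrogen reads the same alongside the chloro or bromo of compound 1 and compound 2 remains open. So does the reading of a longer acyl chain, a methyl group or a sulfonamide on that nitrogen.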